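The source may hold more compounds than are shown below. What is called first, only, known or untested is meant among the compounds shown, and "the series" means these compounds.

Compound 1 `O=C(NC1CCN(Cc2ccc3ccccc3c2)CC1)c1ccccc1` and compound 2 `O=C(NC1CCN(Cc2ccc3ccccc3c2)CC1)c1ccc(F)cc1` share one core and differ at a single point. In an assay on isolated protein for binding affinity to melanin-concentrating hormone receptor 1 (Homo sapiens) (a lower number here means a stronger inhibitor, a higher number a weaker inhibitor), compound 1 gives 347 nM, while compound 2 gives 36 nM; the change fluoro in place of hydrogen on an aromatic carbon brought a 9.6-fold lower number from compound 1 to compound 2 (0.98 log units; beyond the scatter). Compound 3 `COc1cccc(C(=O)N[C@@H]2CCN(Cc3ccc4ccccc4c3)C2)c1` has a different core, and the difference between the two cores is not broken down here; in this assay compound 3 gives 67 nM. Compound 4 `COc1cc(C(=O)N[C@@H]2CCN(Cc3ccc4ccccc4c3)C2)ccc1F` is not yet measured. It differs from compound 3 by fluoro in place of hydrogen on an aromatic carbon, the same kind of change as before, though here the entering fluoro sits ortho to a methoxy group as well as para to a large group. The step is expected to be a 2.7-fold lower number from compound 3 to compound 4 (0.43 log units; beyond the scatter), somewhat smaller than the earlier one. This expectation rests on the size of a 9.6-fold lower number from compound 1 to compound 2 (0.98 log units; beyond the scatter) and on the surroundings differing. Compound 4 is therefore estimated at 25 nM, between 8 nM and 70 nM.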

Compound 4, inhibition constant: 62 nM
Beside the measured number, compound 4's estimate is 2.5-fold (0.39 log units) below it; the range from low to high includes it.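

In this assay, adding the fluoro to the core of compound 3 gave a 1.1-fold lower number from compound 3 to compound 4 (0.03 log units; within the scatter), so this step shows no real effect. The same change therefore did not carry over with the same size, and the two steps clearly differ: the same change on two cores in this assay, a 9.6-fold lower number (0.98 log units; beyond the scatter) from compound 1 to compound 2 and a 1.1-fold lower number (0.03 log units; within the scatter) from compound 3 to compound 4, 8.9-fold (0.95 log units) apart, beyond the scatter of two such steps

This shows that the step measured on one core cannot simply be transferred to the other in this series, but it does not show what causes the difference, since the two pairs differ both in their cores and in the methoxy group.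

The compounds shown leave open whether the fluoro would give a larger step on the core of compound 3 without the methoxy group. They also leave open whether a chloro or nitrile group in the same place would alter the number on that core.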